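A few compounds are considered here, and "the series" means these few. Any claim that something is new, unique, unknown or untested is made for them only; others in the source may bear on it.

Notes on the aryl group carried by the amine nitrogen of the shared core. In a functional assay, with a stated time of 6 min (on this read-out lower numbers stand for stronger inhibition and higher numbers for weaker inhibition), compound 1 `S=c1oc(-c2ccc3c(c2)OCCO3)nn1CNc1ccccc1` gives 5140 nM. In this assay compound 2 `Fc1ccc(NCn2nc(-c3ccc4c(c3)OCCO4)oc2=S)cc1` gives 6480 nM. In this assay compound 3 `Fc1cc(NCn2nc(-c3ccc4c(c3)OCCO4)oc2=S)cc(F)c1F` gives 2920 nM. Compound 3 thus holds the lowest of the three numbers; its gap to compound 1 is within the scatter, its gap to compound 2 beyond it. The single-point steps are a 1.3-fold higher number from compound 1 to compound 2 (0.10 log units; within the scatter), a 1.8-fold lower number from compound 1 to compound 3 (0.25 log units; within the scatter) and a 2.2-fold lower number from compound 2 to compound 3 (0.35 log units; beyond the scatter).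

Compound 4 `S=c1oc(-c2ccc3c(c2)OCCO3)nn1CNc1ccc(Br)cc1` has not yet been measured. It differs from compound 3 by 4-bromophenyl in place of 3,4,5-trifluorophenyl on an amine nitrogen. The step that most resembles this change, a single halogen added to the aryl ring, is a 1.3-fold higher number from compound 1 to compound 2 (0.10 log units; within the scatter), which stayed within the scatter. The modest gain of the trifluorophenyl shows only in a 2.2-fold lower number from compound 2 to compound 3 (0.35 log units; beyond the scatter); against the plain phenyl, in a 1.8-fold lower number from compound 1 to compound 3 (0.25 log units; within the scatter), it stays within the scatter. A single bromine on the ring is therefore expected to land the number near those of compound 1 and compound 2 rather than below compound 3. In this assay compound 4 is expected to give about 4500 nM, within a range of 2000 nM to 10000 nM. The expected step is a 1.5-fold higher number from compound 3 to compound 4 (0.19 log units; within the scatter), a somewhat higher number that may well fall within the scatter.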

Compound 4, half-maximal inhibitory concentration: 14700 nM
Beside the measured number, compound 4's estimate is 3.3-fold (0.51 log units) below it; measured number outside the range, above it.
By their numbers in this assay, from the lowest: compounds 3, 1 and 2 (each within the scatter of the next, the first and the last beyond it); then compound 4.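

In this assay the identity of a single halogen on the aryl group at the amine nitrogen now matters: bromo in place of hydrogen gives a 2.9-fold higher number from compound 1 to compound 4 (0.46 log units; beyond the scatter) and bromo in place of fluoro gives a 2.3-fold higher number from compound 2 to compound 4 (0.36 log units; beyond the scatter), whereas fluoro in place of hydrogen gave only a 1.3-fold higher number from compound 1 to compound 2 (0.10 log units; within the scatter) and stayed within the scatter. The change from the trifluorophenyl group to the 4-bromophenyl group is the largest step in the set, a 5.0-fold higher number from compound 3 to compound 4 (0.70 log units; beyond the scatter), and compound 4 has the weakest inhibition of the four, with its steps to all three others beyond the scatter. Nothing available accounts for the loss seen with bromine at this position.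

With only fluoro and bromo shown as single substituents, it remains open whether 4-chlorophenyl would fall near compound 2 or near compound 4, and so whether the number rises gradually along the halogens or only with bromine. Also open, as far as these compounds go, is whether the aromatic ring is needed at all, a question that a cyclohexyl group on the amine nitrogen would address.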